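Urea side chain variation on the shared core: piperazine analogue

The source may report more compounds than this note shows. Statements on the series, on what has been measured and on what is new or still open speak of the compounds shown alone.

Measured so far in a functional assay on A-431 cells (Homo sapiens) for antiproliferative activity, read by sulforhodamine B assay, with a stated time of 72 h; a higher number here means a weaker inhibitor, a lower number a stronger inhibitor:
compound 1 `COCCCNC(=O)Nc1cc2c(Nc3ccc(F)c(Cl)c3)ncnc2cc1O[C@H]1CCOC1` gives 4100 nM
compound 2 `CN(C)CCCNC(=O)Nc1cc2c(Nc3ccc(F)c(Cl)c3)ncnc2cc1O[C@H]1CCOC1` gives 226 nM
compound 3 `CCN(CC)CCN(C)C(=O)Nc1cc2c(Nc3ccc(F)c(Cl)c3)ncnc2cc1O[C@H]1CCOC1` gives 481 nM

Compound 1, which carries the (3-methoxypropyl)amino group on the urea carbonyl carbon, has the highest number of the three in this assay. Compound 2, with dimethylamino in place of methoxy on the chain, and compound 3, with an amine-bearing group on the carbonyl carbon, both sit well below it.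

Compound 4 `CN1CCN(C(=O)Nc2cc3c(Nc4ccc(F)c(Cl)c4)ncnc3cc2O[C@H]2CCOC2)CC1` is the next member. Its change from compound 1 is 4-methylpiperazin-1-yl in place of (3-methoxypropyl)amino on a carbonyl carbon. This is an amine-bearing group entering at the same carbonyl carbon as in compounds 2 and 3, so the steps of an 18-fold lower number from compound 1 to compound 2 (1.26 log units; beyond the scatter) and an 8.5-fold lower number from compound 1 to compound 3 (0.93 log units; beyond the scatter) bear most directly on it. Both point the same way, with the ring-free, donor-bearing chain of compound 2 giving the larger move and the tertiary-nitrogen-substituted urea of compound 3 the smaller one; the gap between those two is given by a 2.1-fold higher number from compound 2 to compound 3 (0.33 log units; beyond the scatter). Compound 4 has no hydrogen-bond donor in the entering group, as compound 3 has none, so a step of the size seen for compound 3 is expected rather than that for compound 2. The expected step is a 7.5-fold lower number from compound 1 to compound 4 (0.87 log units; beyond the scatter). Compound 4 is therefore estimated at 550 nM, with a range of 180 nM to 1700 nM.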

Compound 4, half-maximal inhibitory concentration: 675 nM
The estimate for compound 4 lay 1.2-fold (0.09 log units) below the measured number; the measured number falls inside the stated range.
By their numbers in this assay, from the lowest: compound 2; then compounds 3 and 4 (each within the scatter of the next); then compound 1.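

In this assay, 4-methylpiperazin-1-yl on the carbonyl carbon gives a 6.1-fold lower number from compound 1 to compound 4 (0.78 log units; beyond the scatter), so an amine-bearing group held in a six-membered non-aromatic ring moves the number in the same direction as the open-chain amine groups of compound 2 and compound 3. The two entering groups without a hydrogen-bond donor are not separated, with a 1.4-fold higher number from compound 3 to compound 4 (0.15 log units; within the scatter), while a 3.0-fold higher number from compound 2 to compound 4 (0.48 log units; beyond the scatter); compound 2 thus stands apart from both, although a donor alone does not account for the series, as compound 1 also has one in its entering group and has the highest number. No measurement shown here gives an explanation for these steps.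

As far as these compounds go, compound 4 changes the ring and the hydrogen-bond donor together, so their separate contributions remain open; a (1-methylpiperidin-4-yl)amino group on the same carbonyl carbon would pair a ring with a urea hydrogen. From the compounds shown here alone, whether the ring's second nitrogen matters also remains open, and a morpholin-4-yl group at this carbon would put oxygen in its place.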